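Cytotoxicity notes: from compound 2 to compound 4

The source may report more compounds than this note shows. Statements on the series, on what has been measured and on what is new or still open speak of the compounds shown alone.

Measured so far in a functional assay on MT4 cells (Homo sapiens) for cytotoxicity, read by MTT assay; a lower number here means that less compound is tolerated, a higher number that more compound is tolerated:
compound 1 `COc1ccc(CSc2nc(O)c(C)c(Cc3ccc(F)cc3)n2)cc1`: 8900 nM
compound 2 `CCOc1ccc(CSc2nc(O)c(C)c(Cc3c(Cl)cccc3Cl)n2)cc1`, reported as a limit: > 58000 nM
compound 3 `COc1ccc(CCSc2nc(Cc3c(Cl)cccc3Cl)c(C)c(=O)[nH]2)cc1`, reported as a limit: > 57000 nM

Compound 2 stands at a limit of this assay rather than at a number; the same holds for (the limit of > 58000 nM in this assay, at which 1 of the 3 values shown sits), and one further value sits at the limit of > 57000 nM in this assay, at which 1 of the 3 values shown sits. Only compound 1 returns a number in this assay. For the measured compounds named here, no pair of measured compounds differs in a single place, so no measured step is available to set the size of a change.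

Compound 4 `Cc1c(O)nc(SCc2cccc(Cl)c2)nc1Cc1c(Cl)cccc1Cl` is not yet measured in this assay. The change from compound 2 is 3-chlorophenyl in place of 4-ethoxyphenyl on a saturated chain carbon bound to a sulfur.

With nothing to calibrate against, the expectation rests on compound 2 alone, whose reading in this assay is a limit. The expected step is an at least 1.4-fold lower number from compound 2 to compound 4 (0.16 log units; that floor lies within the scatter), which, if the assay again reports a limit, would amount to no change beyond the scatter. Compound 4 is estimated at 40000 nM in this assay, within a range of 10000 nM to 100000 nM, with a fair chance that only a limit is reported again.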

Compound 4, half-maximal cytotoxic concentration: > 59000 nM
Compound 4 ended at the assay's limit; the forecaster's own chance of this, stated with the estimate: 55%; middle value at least 1.4-fold (0.16 log units) away from the limit.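

In this assay compound 4 gives > 59000 nM, which is a limit. Compound 2 also gives a limit, > 58000 nM. The step between compound 2 and compound 4 therefore cannot be read. The compounds shown leave open whether 3-chlorophenyl in place of 4-ethoxyphenyl changes the reading in this assay at all.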